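Swapping methoxy for nitro on the chalcone of compound 1

The compounds below may be only part of what the source reports. "The series", "measured", "known", "first", "only" and "open" are said of these compounds alone.

Measured so far:
compound 1, `COc1ccc(C(=O)/C=C/c2ccc(OCc3cn(Cc4ccccc4Br)nn3)cc2)cc1`, 44%
compound 2, `COc1ccc(C(=O)/C=C/c2ccc(OCc3cn(Cc4ccccc4F)nn3)cc2)cc1`, 33%

Of the compounds shown here, two have been tested in a functional assay on HepG2 cells (Homo sapiens) for inhibition, read by MTT assay, with a stated time of 48 h, tested at 10 uM; on this read-out lower numbers stand for less inhibition of growth and higher numbers for more inhibition of growth at the one concentration tested. Compound 1 gives 44%, the higher of the two numbers; compound 2 gives 33%. Among the measured compounds shown here, the one step between them, a number 11 percentage points lower from compound 1 to compound 2 (beyond the scatter), is a fluoro in place of bromo on an aromatic carbon.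

Compound 3, `O=C(/C=C/c1ccc(OCc2cn(Cc3ccccc3Br)nn2)cc1)c1ccc([N+](=O)[O-])cc1`, has not yet been measured. It differs from compound 1 by nitro in place of methoxy on an aromatic carbon, in words nitro in place of methoxy on an aromatic carbon. No measured step touches this part of the shared core: the only step shown concerns the halogen elsewhere in the molecule, and it was modest. There is therefore nothing in the data that points to a large move in either direction in this assay , and the expectation is a step of about a number 1 percentage points higher from compound 1 to compound 3 (within the scatter), within the scatter. Compound 3 is accordingly expected at 45%, in the range 25% to 65%.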

Compound 3, percent growth inhibition at one concentration: 32%
The estimate for compound 3 lay 13 percentage points above the measured number; low and high end bracket the measured number.
By their numbers in this assay, from the lowest: compounds 3 and 2 (each within the scatter of the next); then compound 1.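

In this assay, going from 4-methoxyphenyl to 4-nitrophenyl gives a number 12 percentage points lower from compound 1 to compound 3 (beyond the scatter), so this place on an aromatic carbon of a six-membered aromatic ring of carbon only is not indifferent to the group it carries. The halogen change alone had shown a step beyond the scatter; this result shows that a change in a second part of the molecule, para to a large group, can also lower the number, and that the methoxy of compound 1 cannot be replaced by nitro without a modest loss of growth inhibition at the one concentration tested. Nothing available explains why the number falls with this exchange.

The compounds shown leave open whether the lower number comes from the arrival of nitro or from the departure of methoxy, a question that an amine, a hydroxyl or a longer chain such as ethoxy at the same place would help to settle. They also leave open whether the nitro exchange would have a step of similar size when the bromo of compound 1 is replaced by the fluoro of compound 2.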